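Methylating the phenol of compound 3

The compounds below may be only part of what the source reports. "The series", "measured", "known", "first", "only" and "open" are said of these compounds alone.

All three measured compounds share one core. Compound 1 `COc1cc(Cl)cc(-c2nn(-c3cccc(NC(=O)Nc4ccc(Cl)c(C(F)(F)F)c4)c3)cc2-c2ccncc2)c1` gives -22.6% in a functional assay on OVCAR-3 cells (Homo sapiens) for inhibition, read by sulforhodamine B assay, with a stated time of 48 h, tested at 10 uM; a higher number here means a weaker effect of the compound at the concentration tested, a lower number a stronger effect; compound 2 `COc1cc(Cl)cc(-c2nn(-c3cccc(NC(=O)c4cccc(C(F)(F)F)c4)c3)cc2-c2ccncc2)c1` gives 52.3%; compound 3 `O=C(Nc1cccc(-n2cc(-c3ccncc3)c(-c3cc(O)cc(Cl)c3)n2)c1)c1cc(C(F)(F)F)cc(C(F)(F)F)c1` gives 15.2%, the second highest of the three numbers, above compound 1 and below compound 2, both gaps beyond the scatter. For the measured compounds named here, the only step between measured compounds, a number 74.9 percentage points higher from compound 1 to compound 2 (beyond the scatter), alters the amide link rather than the phenol and so does not bear on the present change. Compound 4 `COc1cc(Cl)cc(-c2nn(-c3cccc(NC(=O)c4cc(C(F)(F)F)cc(C(F)(F)F)c4)c3)cc2-c2ccncc2)c1` differs from compound 3 by methyl in place of hydrogen on an oxygen on an aromatic ring. Going by the values given here, no measured pair shows this change; with nothing to set a direction, a step of a number 4.8 percentage points higher from compound 3 to compound 4 (within the scatter) is expected, within the scatter. Compound 4 is therefore estimated at 20%, in the range -5% to 45%.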

Compound 4, a percentage reported as activity, at one concentration (the size of the read-out at that concentration, not a potency): 25.5%
Beside the measured number, compound 4's estimate is 5.5 percentage points below it; measured number inside the range.
By their numbers in this assay, from the lowest: compound 1; then compound 3; then compound 4; then compound 2.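

In this assay, for the compounds shown here, the step of a number 10.3 percentage points higher from compound 3 to compound 4 (beyond the scatter) gives the first reading at this position: within this one pair, methoxy carries a weaker effect than hydroxy on the 3-chloro-5-substituted phenyl. The methoxy compounds also respond to the amide side, with the step of a number 26.8 percentage points lower from compound 2 to compound 4 (beyond the scatter) showing a stronger effect with the added trifluoromethyl. No measurement at hand accounts for either step.

On these data alone, whether an ethoxy or an amine at this place would extend the same direction remains open. So does whether hydroxy to methoxy reads the same with the link carried by compound 1.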